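The compounds below may be only part of what the source reports. "The series", "measured", "known", "first", "only" and "open" are said of these compounds alone.

Measured so far:
compound 1, `CCO[C@@]1(CC)CCC2(CO1)[C@@H]1CCC3=C4[C@H](CC3=O)[C@H](C(=O)OC)C[C@@]42CN(C)C1`: > 40000 nM
compound 2, `CCC1=CCC2(CO1)[C@@H]1CCC3=C4[C@H](CC3=O)[C@H](C(=O)OC)C[C@@]42CN(C)C1`: > 40000 nM

Both values are limits of the assay rather than numbers. In a functional assay on SW480 cells (Homo sapiens) for cytotoxicity, read by MTT assay, with a stated time of 48 h (a higher number here means a weaker inhibitor, a lower number a stronger inhibitor), compound 1 reaches only the limit > 40000 nM. In this assay compound 2 likewise stops at the limit > 40000 nM. Compound 2 thus stands together with compound 1 at the limit of > 40000 nM in this assay, at which 2 of the 2 values shown sit, and no ordering between the two can be read from these figures. Compound 3, `COC(=O)[C@@H]1C[C@@]23CN(C)C[C@@H](CCC4=C2[C@@H]1CC4=O)C31CC=C(C(C)C)OC1`, has not yet been measured in this assay. Its difference from compound 2 is methyl in place of hydrogen on a saturated chain carbon bound to a double-bonded ring carbon and a saturated chain carbon. No step between measured compounds is available, and nothing among the shown values speaks for a move out of the limit region. The step from compound 2 to compound 3 in this assay is expected to be a number no higher from compound 2 to compound 3 (the limit leaves the size open), that is, none beyond the scatter. Compound 3 is therefore estimated at 40000 nM, within 15000 nM to 120000 nM, most probably again reported only as a limit.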

Compound 3, half-maximal inhibitory concentration: > 40000 nM
Compound 3: no number, only a limit; the forecaster's own chance of this, stated with the estimate: 80%; the middle value sits exactly at the limit.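

Among the compounds shown here, compound 2 and compound 3 both stop at a limit of this assay, so no step between them can be read. The compounds shown leave open how strongly any of them acts and whether ethyl to isopropyl makes any difference: the limit of > 40000 nM in this assay, at which 3 of the 3 values shown sit.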